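Moving the Methyl and Dropping the Chloro on the Ester Aryl

A few compounds are considered here, and "the series" means these few. Any claim that something is new, unique, unknown or untested is made for them only; others in the source may bear on it.

Three esters share a core, differing only in the aryl group on the carbonyl carbon. Compound 1 `Cc1ccccc1C(=O)OC(CCN(C)C)c1ccc(Cl)cc1` gives 126% in an assay on NIH3T3 cells with Urotensin-2 receptor (Homo sapiens) as the target (on this read-out higher numbers stand for larger maximal responses and lower numbers for smaller maximal responses), compound 2 `CCc1ccccc1C(=O)OC(CCN(C)C)c1ccc(Cl)cc1` gives 128%, and compound 3 `Cc1c(Cl)cccc1C(=O)OC(CCN(C)C)c1ccc(Cl)cc1` gives 118%. The number for compound 3 is the lowest of the three, yet a number 8 percentage points lower from compound 1 to compound 3 (within the scatter) and a number 10 percentage points lower from compound 2 to compound 3 (within the scatter) both lie within the scatter, so the three compounds cannot be told apart on this read-out. Compound 4 `Cc1ccc(C(=O)OC(CCN(C)C)c2ccc(Cl)cc2)cc1` has not yet been measured; it differs from compound 3 in that (4-methylphenyl in place of 3-chloro-2-methylphenyl on a carbonyl carbon). Among the compounds with values here, two measured steps bear on this change: a number 8 percentage points lower from compound 1 to compound 3 (within the scatter), which is the reverse of removing the chloro, and a number 10 percentage points lower from compound 2 to compound 3 (within the scatter), the only other exchange of the whole aryl group. Within the data shown here, both were within the scatter, and no measured step addresses a methyl on a different aromatic carbon. Compound 4 is therefore expected to show a number 6 percentage points higher from compound 3 to compound 4 (within the scatter), with the estimate for compound 4 being 124% within a range from 106% to 142%.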

Compound 4, largest response reached (reported as efficacy), in percent of the reference or control that the assay uses: 56%
Beside the measured number, compound 4's estimate is 68 percentage points above it; measured number outside the range, below it.
By their numbers in this assay, from the lowest: compound 4; then compounds 3, 1 and 2 (each within the scatter of the next).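

Within the data shown here, the aryl group on the carbonyl carbon proves far less tolerant in this assay than the earlier compounds suggested: 4-methylphenyl gives a number 62 percentage points lower from compound 3 to compound 4 (beyond the scatter) and a number 72 percentage points lower from compound 2 to compound 4 (beyond the scatter) as well as a number 70 percentage points lower from compound 1 to compound 4 (beyond the scatter) in the closest comparison of the three. That last step changes only where the methyl sits on the aryl ring, so among these compounds 2-methylphenyl, 2-ethylphenyl and 3-chloro-2-methylphenyl stand together, with 4-methylphenyl alone far lower. Nothing measured here accounts for this loss of maximal response.

The compounds shown leave open whether the loss belongs to the methyl in 4-methylphenyl or extends to other groups. A plain phenyl, 3-methylphenyl, 4-chlorophenyl or 4-methoxyphenyl on the carbonyl carbon would help separate these possibilities.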